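The source may report more compounds than this note shows. Statements on the series, on what has been measured and on what is new or still open speak of the compounds shown alone.

Of the compounds shown here, three built on one shared core have been tested in a functional assay on HCT-116 cells (Homo sapiens) for inhibition, read by MTT assay, with a stated time of 72 h; on this read-out lower numbers stand for stronger inhibition of growth and higher numbers for weaker inhibition of growth. Compound 1 `O[C@H](COCCOC[C@@H](O)Cc1cn(Cc2ccc(Oc3ccccc3)cc2)nn1)Cc1ccc(-c2ccccc2)cc1` gives 3400 nM in this assay, and compound 2 `CC1=C(CCCCCCCCCCn2cc(C[C@H](O)COCCOC[C@@H](O)Cc3ccc(-c4ccccc4)cc3)nn2)C(=O)c2ccccc2C1=O` gives 3000 nM in this assay, two values that lie within the usual scatter of each other. Compound 3 `O[C@H](COCCOC[C@@H](O)Cc1cn(-c2ccc3c(c2)OCCO3)nn1)Cc1ccc(-c2ccccc2)cc1` gives 16500 nM in this assay, the highest of the three numbers; compound 1 stands nearest to it and compound 2 furthest, and both gaps are beyond the scatter, so compound 3 is the weakest growth inhibitor of the measured set.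

Compound 4 `O=c1[nH]c2ccc(-n3cc(C[C@H](O)COCCOC[C@@H](O)Cc4ccc(-c5ccccc5)cc4)nn3)cc2s1` differs from compound 3 by a group of 10 heavy atoms (7 carbon, 1 nitrogen, 1 oxygen, 1 sulfur; one five-membered aromatic ring with 2 hetero atoms, one six-membered aromatic ring of carbon only) in place of a group of 10 heavy atoms (8 carbon, 2 oxygen; one six-membered non-aromatic ring with 2 hetero atoms, one six-membered aromatic ring of carbon only), on an aromatic nitrogen. The two groups are alike in heavy-atom count and in carrying one six-membered aromatic ring of carbon only; what changes is that a five-membered aromatic ring with 2 hetero atoms takes the place of the six-membered non-aromatic ring with 2 hetero atoms, and one hydrogen-bond donor enters. Among the compounds with values here, no two measured compounds differ in a single place, so no measured step speaks directly to this change. The author expects the step of a 1.5-fold lower number from compound 3 to compound 4 (0.18 log units; within the scatter) to be small, toward lower numbers, and quite possibly not beyond the scatter. Compound 4 is therefore estimated to give 11000 nM in this assay, within a range from 4500 nM to 27000 nM.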

Compound 4, concentration for 50% growth inhibition: 9200 nM
Compound 4: the middle estimate sits 1.2-fold (0.08 log units) above what was measured, within the range that was stated.
By their numbers in this assay, from the lowest: compounds 2 and 1 (each within the scatter of the next); then compounds 4 and 3 (each within the scatter of the next).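

In this assay the exchange gives a 1.8-fold lower number from compound 3 to compound 4 (0.25 log units; within the scatter) and so, on an aromatic nitrogen, the 2,3-dihydro-1,4-benzodioxin-6-yl group and the group that replaces it cannot be told apart. Within the data shown here, this is the first measured step in a single place, and it shows that a five-membered aromatic ring with 2 hetero atoms can take the place of the six-membered non-aromatic ring with 2 hetero atoms, with one hydrogen-bond donor entering, without a change beyond the scatter. No other measurement on hand bears on this result.

The compounds shown leave open whether the ring exchange and the entering donor each have an effect of their own that the combined step hides, since no pair separates them. They also leave open how the growth inhibition would respond to a methyl group in place of the hydrogen on the nitrogen of the entering group, or to a plain phenyl or a carboxylic acid-bearing phenyl on the same aromatic nitrogen.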